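The source may report more compounds than this note shows. Statements on the series, on what has been measured and on what is new or still open speak of the compounds shown alone.

Measured so far:
- compound 1, `COc1ccc(C)cc1N1C(=O)CSC1c1cccc(C(=O)NCCCCc2ccccc2)c1`: 95%
- compound 2, `COc1ccccc1N1C(=O)CSC1C(=O)NCCCCc1ccccc1`: 0%
- compound 3, `COc1ccc(F)cc1N1C(=O)CSC1c1cccc(C(=O)NCCCCc2ccccc2)c1`: 95%

In a functional assay on HOS-TE85 cells (Homo sapiens) for inhibition, read by CCK-8 assay, with a stated time of 72 h, tested at 1 uM (a lower number here means less inhibition, a higher number more inhibition at the concentration tested (going by the name of the read-out)), compound 3 stands level with compound 1, and the two together give the highest of the three numbers; the step of no change at the digits printed from compound 1 to compound 3 (within the scatter) shows that swapping fluoro in place of methyl on an aromatic carbon leaves the read-out unchanged within the scatter. Compound 2, which differs from compound 3 in more than one place and so allows no single-step comparison, gives a number far lower.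

Compound 4, `CCN1C(=O)CSC1c1cccc(C(=O)NCCCCc2ccccc2)c1`, is not yet measured. It differs from compound 3 by ethyl in place of 5-fluoro-2-methoxyphenyl on an amide-type nitrogen in a ring. Among the measured compounds shown here, no measured step changes this position, so the only guidance is indirect: the one step known, from compound 1 to compound 3, varied the substituent on the group that now leaves entirely and showed no change. Replacing the whole ring with ethyl is a larger change than that, and the low number of compound 2 warns that the read-out can collapse. A drop is therefore expected, of size a number 40 percentage points lower from compound 3 to compound 4 (beyond the scatter), with wide uncertainty. For compound 4 the estimate in this assay is 55%, ranging from 10% to 95%.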

Compound 4, a percentage reported as inhibition, at one concentration (the size of the read-out at that concentration, not a potency): 0%
The estimate for compound 4 lay 55 percentage points above the measured number, and the stated range ends above it.
By their numbers in this assay, from the lowest: compounds 2 and 4 (each within the scatter of the next); then compounds 1 and 3 (each within the scatter of the next).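

In this assay, among the compounds shown here, the earlier compounds showed only that a small substituent on the phenyl ring could change, from methyl to fluoro, with no visible effect. This result tests the whole group on the amide-type nitrogen in the ring: ethyl in place of 5-fluoro-2-methoxyphenyl gives a number 95 percentage points lower from compound 3 to compound 4 (beyond the scatter), and ethyl in place of 2-methoxy-5-methylphenyl gives a number 95 percentage points lower from compound 1 to compound 4 (beyond the scatter), so in this series the read-out depends on what sits at this position, and a small ethyl group does not preserve it. Nothing available here explains why the read-out is lost with this change.

The compounds shown leave open whether a plain phenyl, a benzyl or a longer chain such as butyl at this nitrogen would retain the read-out. They also leave open whether the methoxy group on the phenyl ring is needed.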